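Ester in place of pyridyl acid on the shared core

This account rests on a few compounds, and the source may have more. Where it says the series, first, only, none or still open, it means among the compounds named here.

Compound 1 `O=C(O)c1cc(-c2cnc(C(=O)CCc3ccc(-c4ccccc4)cc3)o2)ccn1` gives 50 nM in an assay for inhibition of Fatty-acid amide hydrolase 1 (Rattus norvegicus); on this read-out lower numbers stand for stronger inhibition and higher numbers for weaker inhibition.
Compound 2 `CN(C)C(=O)c1cnc(C(=O)CCc2ccc(COc3ccccc3)cc2)o1` gives 6.7 nM in this assay.
Compound 3 `O=C(O)c1ccc(-c2cnc(C(=O)CCc3ccc(COc4ccccc4)cc3)o2)nc1` gives 4.6 nM in this assay.

Compound 1 stands highest of the three numbers in this assay; compound 2 lies well below it, and compound 3 lies further below still, both gaps beyond the scatter. Compound 4 `COC(=O)c1cnc(C(=O)CCc2ccc(-c3ccccc3)cc2)o1` has not yet been measured. It differs from compound 1 in one place: methoxycarbonyl in place of 2-carboxypyridin-4-yl on an aromatic carbon.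

Among the compounds with values here, only one measured step bears on this change. From compound 2 to compound 3 a small group on the five-membered aromatic ring was replaced by a large one bearing a carboxylic acid, and the result was a 1.5-fold lower number from compound 2 to compound 3 (0.16 log units; within the scatter). The step from compound 1 to compound 4 goes the other way, from a large acid-bearing group to a small methoxycarbonyl group, though on a different tail, so the comparison is loose. On this basis compound 4 is expected to show at most a modest shift, a 1.7-fold lower number from compound 1 to compound 4 (0.22 log units; within the scatter), if any beyond the scatter. The estimate for compound 4 is 30 nM, within a range of 8 nM to 110 nM.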

Compound 4, inhibition constant: 1.5 nM
For compound 4 the middle estimate is 20-fold (1.30 log units) above the measured one; the measured number lies below the stated range.
By their numbers in this assay, from the lowest: compound 4; then compounds 3 and 2 (each within the scatter of the next); then compound 1.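

In this assay, a 33-fold lower number from compound 1 to compound 4 (1.52 log units; beyond the scatter) shows that the group on the aromatic carbon next to the ring oxygen can strongly change the number. The only earlier step at this place, a 1.5-fold lower number from compound 2 to compound 3 (0.16 log units; within the scatter), had shown no readable change, although it belongs to a different remainder of the molecule and so shows only that the effect of a change here is not the same in every case. The present step goes with the loss of a six-membered aromatic ring and of a hydrogen-bond donor, and with a fall in heavy atoms, but no measurement shown here accounts for its size.

Because these differences arrive together in one exchange, the compounds shown leave open which of them goes with the lower number, and a plain pyridin-4-yl group or a methyl ester on the same pyridine ring would separate the ring from the carboxylic acid. From the compounds shown here alone, it also remains open whether methoxycarbonyl is specially favoured at this place or whether another small group, such as a nitrile or a primary amide, would give a similar number on the core of compound 4.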